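The source may hold more compounds than are shown below. What is called first, only, known or untested is meant among the compounds shown, and "the series" means these compounds.

Measured so far in a functional assay on cells (Homo sapiens) for antiproliferative activity, read by WST assay, with a stated time of 3 days; a higher number here means a weaker inhibitor, a lower number a stronger inhibitor:
compound 1 `N#Cc1cc(=O)[nH]c(=O)n1[C@@H]1O[C@H](CO)[C@@H](O)[C@H]1O`: > 50000 nM (a limit)
compound 2 `CNc1cc(=O)[nH]c(=O)n1[C@@H]1O[C@H](CO)[C@@H](O)[C@H]1O`: > 50000 nM (a limit)

Compound 2 gives > 50000 nM in this assay, which is a limit and not a number. Compound 1 gives > 50000 nM, also a limit. Neither compound therefore has a readable value, and the series stands at the limit of > 50000 nM in this assay, at which 2 of the 2 values shown sit.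

The next change leads to compound 3 `O=Cc1cc(=O)[nH]c(=O)n1[C@@H]1O[C@H](CO)[C@@H](O)[C@H]1O`, with formyl in place of methylamino on an aromatic carbon.

Going by the values given here, only one measured step bears on this change: a step that the two limits leave unreadable from compound 1 to compound 2. It has no readable size, so it offers no magnitude to carry over and gives no direction for this assay. It shows only that the cyano and methylamino compounds both end at the same limit, as recorded in the limit of > 50000 nM in this assay, at which 2 of the 2 values shown sit. On that basis, compound 3 is expected to show no clear gain over compound 2, and a reported limit is the likeliest outcome.

The expected change is a number no higher from compound 2 to compound 3 (the limit leaves the size open), an estimate measured against a limit.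

For compound 3 the estimated half-maximal inhibitory concentration is 50000 nM, with an expected range of 15000 nM to 100000 nM.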

Compound 3, half-maximal inhibitory concentration: > 50000 nM
Compound 3 ended at the assay's limit; the forecaster's own chance of this, stated with the estimate: 75%; the middle value lies on the limit itself.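

In this assay compound 3 gives > 50000 nM, which is a limit. Going by these compounds alone, no step among compound 1, compound 2 and compound 3 can be read, and all three compounds end the same way: the limit of > 50000 nM in this assay, at which 3 of the 3 values shown sit. The compounds shown leave open whether any group at this place on the shared core gives a readable half-maximal inhibitory concentration in this assay.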